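Bromo in Place of Trifluoromethyl on the Benzyl Ring

The source may hold more compounds than are shown below. What is called first, only, known or untested is meant among the compounds shown, and "the series" means these compounds.

Of the compounds shown here, three sharing one core have been measured in a toxicity assay on MCF-10A cells (Homo sapiens) for inhibition, read by MTT assay, with a stated time of 72 h; a higher number here means a weaker inhibitor of growth, a lower number a stronger inhibitor of growth. Compound 1 `CC(C)(C)c1ccc(CNCCCNS(=O)(=O)c2cc(C(F)(F)F)cc(C(F)(F)F)c2)cc1` gives 3200 nM, compound 2 `O=S(=O)(NCCCNCc1cccc(Cl)c1)c1cc(C(F)(F)F)cc(C(F)(F)F)c1` gives 7000 nM, and compound 3 `O=S(=O)(NCCCNCc1ccc(C(F)(F)F)cc1)c1cc(C(F)(F)F)cc(C(F)(F)F)c1` gives 3300 nM. Compound 3 stands second highest of the three numbers; its nearest neighbour is compound 1, a difference within the scatter, while compound 2 sits further off, beyond the scatter.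

Compound 4 `O=S(=O)(NCCCNCc1ccc(Br)cc1)c1cc(C(F)(F)F)cc(C(F)(F)F)c1` differs from compound 3 by bromo in place of trifluoromethyl on an aromatic carbon. The change sits on the same aromatic carbon that was already varied: from compound 1 to compound 3 the swap of tert-butyl for trifluoromethyl at that carbon gave a 1.0-fold higher number from compound 1 to compound 3 (0.01 log units; within the scatter), and from compound 2 to compound 3 the move from 3-chlorophenyl to 4-(trifluoromethyl)phenyl gave a 2.1-fold lower number from compound 2 to compound 3 (0.33 log units; beyond the scatter). Both steps are small to modest, so a single-atom bromo in place of trifluoromethyl in this assay is expected to move the number little, if at all, beyond the scatter, with a slight lean toward a higher number on the strength of the step from compound 2.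

Compound 4 is therefore expected to give 4200 nM, in a range from 2000 nM to 8500 nM, which means an expected step of a 1.3-fold higher number from compound 3 to compound 4 (0.10 log units; within the scatter).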

Compound 4, concentration for 50% growth inhibition: 3100 nM
Estimate against measurement, compound 4: 1.4-fold (0.13 log units) above, and the stated range covers the measured number.
By their numbers in this assay, from the lowest: compounds 4, 1 and 3 (each within the scatter of the next); then compound 2.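

In this assay, three different groups have now been read on the same aromatic carbon, para to a large group, and they give values that cannot be told apart: bromo in place of trifluoromethyl (a 1.1-fold lower number from compound 3 to compound 4 (0.03 log units; within the scatter)) and bromo in place of tert-butyl (a 1.0-fold lower number from compound 1 to compound 4 (0.01 log units; within the scatter)) both stay within the scatter. Among the compounds shown here, the earlier compounds showed this for only one pair of groups, whereas a single bromine atom now stands level with the four heavy atoms of trifluoromethyl as well as with tert-butyl. Compound 2 stays apart from this group of three, with 4-bromophenyl in place of 3-chlorophenyl giving a modest step (a 2.3-fold lower number from compound 2 to compound 4 (0.35 log units; beyond the scatter)), but that swap alters both the halogen and where it sits, so it cannot separate the two.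

Nothing available here bears on why these groups read alike. The compounds shown also leave open whether an amine, a carboxylic acid or a methoxy group on this same aromatic carbon would stay level with these three, and whether 3-bromophenyl would match compound 2 or compound 4.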